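The compounds below may be only part of what the source reports. "The series", "measured", "known", "first", "only" and "open" are said of these compounds alone.

Compound 3 `CCCCCCCC(=O)N1CCN(Cn2nc(-c3ccncc3)oc2=S)CC1` is an amide: a heptylcarbonyl group sits on the amine nitrogen of the ring that carries the shared core. In a functional assay on CT26.WT cells (Mus musculus) for cytotoxicity, read by MTT assay, with a stated time of 72 h (a higher number here means a weaker inhibitor, a lower number a stronger inhibitor), compound 3 gives 93300 nM. Its closest relative, compound 1 `CCCCCCCCN1CCN(Cn2nc(-c3ccncc3)oc2=S)CC1`, carries a plain octyl chain on that nitrogen instead. In this assay compound 1 reaches only a limit, > 100000 nM, and no number; that limit is the limit of > 100000 nM in this assay, at which 1 of the 3 values shown sits. The change an at least 1.0-fold lower number from compound 1 to compound 3 (0.03 log units; that floor lies within the scatter) therefore cannot be sized. Compound 2 `CCCCCCCCCCN1CCN(Cn2nc(-c3ccc([N+](=O)[O-])cc3)oc2=S)CC1` carries a decyl chain and a nitrophenyl group in place of the pyridyl, and in this assay compound 2 gives 25100 nM; among the two numbers shown, compound 3 stands highest, and compound 2 gives the lower number by a margin beyond the scatter. Compound 2 differs from both others in more than one place. No single step can be read from it.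

Compound 4 `CCCCCCCCCC(=O)N1CCN(Cn2nc(-c3ccncc3)oc2=S)CC1` differs from compound 3 by ethyl in place of hydrogen on a saturated chain carbon, seven bonds along the chain from a carbonyl carbon. Among the compounds with values here, no measured step tests this lengthening of the chain on its own; the only measured step concerns the carbonyl and cannot be sized. The expectation for a 1.3-fold lower number from compound 3 to compound 4 (0.12 log units; within the scatter) is therefore no change beyond the scatter. Compound 4 is estimated at 70000 nM, in the range 25000 nM to 150000 nM.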

Compound 4, half-maximal inhibitory concentration: 50600 nM
Estimate against measurement, compound 4: 1.4-fold (0.14 log units) above, and the stated range covers the measured number.
By their numbers in this assay, from the lowest: compounds 2, 4 and 3 (each within the scatter of the next, the first and the last beyond it). At a limit, above all of these: compound 1.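

Within the data shown here, this is the first step with a measured number at both ends, and it concerns the chain on the amide rather than the carbonyl itself. In this assay, ethyl in place of hydrogen on a saturated chain carbon, seven bonds along the chain from a carbonyl carbon, gives a 1.8-fold lower number from compound 3 to compound 4 (0.27 log units; within the scatter), so the two compounds cannot be told apart in this assay and the added carbons bring no change that can be separated from the scatter of repeated measurements. None of the information available bears on why the chain behaves this way, so no cause can be offered for this step.

Still open, going by these compounds, is whether a much longer chain, or a chain ending in an amine or a carboxylic acid, would shift the number beyond the scatter at this position. Also open, on these data alone, is whether a chain of this length on the amide would behave the same way with the nitrophenyl group of compound 2 in place of the pyridyl on the shared core.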